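The compounds below may be only part of what the source reports. "The series", "measured", "known", "first", "only" and "open" are said of these compounds alone.

Compound 1 `COc1cc(/C=C2\CN(C)C/C(=C\c3ccccc3F)C2=O)cc(OC)c1OC` gives 4340 nM in a functional assay on K562 cells (Homo sapiens) for cytotoxicity, read by MTT assay, with a stated time of 24 h; a higher number here means a weaker inhibitor, a lower number a stronger inhibitor. Compound 2 `CN1C/C(=C\c2cccc([N+](=O)[O-])c2)C(=O)/C(=C/c2ccccc2F)C1` gives 3890 nM in this assay. Compound 3 `COc1cc(/C=C2\CN(C)C/C(=C\c3ccc(F)cc3)C2=O)cc(OC)c1OC` gives 10300 nM in this assay.

Compounds 1 and 3 share a core and differ in one place, (4-fluorophenyl in place of 2-fluorophenyl on a double-bonded chain carbon bound to a double-bonded ring carbon); this change made the step of a 2.4-fold higher number from compound 1 to compound 3 (0.38 log units; beyond the scatter). Compound 2 differs from compound 1 in its core, and that difference is not broken down here; the values of compound 2 and compound 1 lie within the scatter of each other, while compound 3 stands beyond the scatter from compound 2.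

Compound 4 `CN1C/C(=C\c2ccc(F)cc2)C(=O)/C(=C/c2cccc([N+](=O)[O-])c2)C1` has not yet been measured in this assay. It stands to compound 2 as compound 3 stands to compound 1: the change is 4-fluorophenyl in place of 2-fluorophenyl on a double-bonded chain carbon bound to a double-bonded ring carbon, the same change, at the same place. On that basis a similar step is expected. The expected step is a 2.4-fold higher number from compound 2 to compound 4 (0.38 log units; beyond the scatter), resting on compound 1 and compound 3 because the same change there gave a 2.4-fold higher number from compound 1 to compound 3 (0.38 log units; beyond the scatter). Compound 4 is therefore expected to give about 9300 nM in this assay. The estimate for compound 4 is expected to fall between 4500 nM and 19000 nM.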

Compound 4, half-maximal inhibitory concentration: 11300 nM
For compound 4 the middle estimate is 1.2-fold (0.08 log units) below the measured one, and the stated range covers the measured number.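

In this assay, 4-fluorophenyl in place of 2-fluorophenyl on the core of compound 2 gave a 2.9-fold higher number from compound 2 to compound 4 (0.46 log units; beyond the scatter), a step in the same direction as on the core of compound 1. The two steps do not differ in size, so within this small set the change carried from one core to the other and kept its size: the same change on two cores in this assay, a 2.4-fold higher number (0.38 log units; beyond the scatter) from compound 1 to compound 3 and a 2.9-fold higher number (0.46 log units; beyond the scatter) from compound 2 to compound 4, 1.2-fold (0.09 log units) apart, within the scatter of two such steps

For the compounds shown here, this rests on only two cores and one cell assay, so it shows neither that the step would hold on a further core nor why the fluorine's place alters the number.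

The compounds shown leave open whether a chlorine or a trifluoromethyl group in place of the fluorine would give a step of the same kind. They also leave open how the change would behave with an ethyl group or a longer chain in place of the methyl on the nitrogen.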